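Moving the hydroxy group: compound 2 to compound 3

The source may hold more compounds than are shown below. What is called first, only, known or untested is meant among the compounds shown, and "the series" means these compounds.

- compound 1 `O=C(Cc1csc2nc(-c3ccc(Br)cc3)cn12)N/N=C/c1ccccc1` | > 100000 nM | a limit of the assay
- compound 2 `O=C(Cc1csc2nc(-c3ccc(Br)cc3)cn12)N/N=C/c1ccccc1O` | 8320 nM | measured
- compound 3 `O=C(Cc1csc2nc(-c3ccc(Br)cc3)cn12)N/N=C/c1ccc(O)cc1` | not yet measured

Going by the values given here, in a functional assay on CCRF-CEM cells (Homo sapiens) for inhibition, read by sulforhodamine B assay, with a stated time of 48 h (on this read-out lower numbers stand for stronger inhibition of growth and higher numbers for weaker inhibition of growth), compound 2 gives 8320 nM, the only actual number so far. Compound 1 stands at > 100000 nM, which is a limit and not a number.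

Compound 3 carries 4-hydroxyphenyl in place of 2-hydroxyphenyl on a carbon with a double bond to nitrogen. Among the compounds with values here, one measured step bears on this change: an at least 12-fold lower number from compound 1 to compound 2 (1.07 log units; beyond the scatter), with hydroxy in place of hydrogen on an aromatic carbon. That step is large, but it sets hydroxy against hydrogen, not one hydroxy placement against another. Compound 3 keeps the hydroxy, so a value near that of compound 2 at 8320 nM is the expected starting point. Within the data shown here, with no measured 4-hydroxyphenyl compound, a modest shift towards weaker inhibition of growth is expected, and a wide range is needed. The expected change is a 1.8-fold higher number from compound 2 to compound 3 (0.26 log units; within the scatter). For compound 3 the estimated value is 15000 nM, with an expected range from 4000 nM to 60000 nM.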

Compound 3, concentration for total growth inhibition: 79400 nM
For compound 3 the middle estimate is 5.3-fold (0.72 log units) below the measured one; measured number outside the range, above it.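

In this assay the placement of the hydroxy counts, not only its presence: a 9.5-fold higher number from compound 2 to compound 3 (0.98 log units; beyond the scatter), with the same atoms joined differently, so 4-hydroxyphenyl does not keep the level reached with 2-hydroxyphenyl. Set against the compound without a hydroxy, the 4-hydroxyphenyl change gives an at least 1.2-fold lower number from compound 1 to compound 3 (0.10 log units; that floor lies within the scatter), so a hydroxy on this ring does not by itself ensure a gain that can be told from the scatter. The value of compound 1 is a limit and not a number, and this step can be read only as a floor because of where compound 1 stands: the limit of > 100000 nM in this assay, at which 1 of the 3 values shown sits.

The compounds shown do not tell whether the activity of compound 2 at 8320 nM depends on the free hydroxy, since a methoxy or an amine in its place on the same ring does not appear among them. They also leave open whether the same difference between 2-hydroxyphenyl and 4-hydroxyphenyl would hold if the bromine on the shared core were replaced by a chlorine or a methyl group.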